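The source may hold more compounds than are shown below. What is called first, only, known or untested is meant among the compounds shown, and "the series" means these compounds.

In a functional assay on HCT-116 cells (Homo sapiens) for antiproliferative activity (on this read-out lower numbers stand for an effect already at smaller amounts and higher numbers for an effect only at larger amounts of compound), compound 2 `CC(=O)NCC(=O)N1CCc2c(C)c3c(n2-c2ccc(C(N)=O)c(c2)N[C@@H](C)CC1)CC(C)(C)CC3=O` gives 1550 nM, the higher of the two actual numbers in the series. Compound 1 `Cc1c2c(n3c1CCN(C(=O)[C@H](C)N)CC[C@H](C)Nc1cc-3ccc1C(N)=O)CC(C)(C)CC2=O` gives 314 nM. Among the compounds with values here, compound 3 `Cc1c2c(n3c1CCCN(CCN)C(=O)[C@H](C)Nc1cc-3ccc1C(N)=O)CC(C)(C)CC2=O` is reported only as a limit, > 20000 nM, and no single-place step connects it to the others.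

Compound 4 `Cc1c2c(n3c1CCN(C(=O)CN)CC[C@H](C)Nc1cc-3ccc1C(N)=O)CC(C)(C)CC2=O` differs from compound 2 by hydrogen in place of acetyl on an amine nitrogen, which also reads as acetamidomethyl to aminomethyl. Within the data shown here, the one measured step that bears on this is a 4.9-fold higher number from compound 1 to compound 2 (0.69 log units; beyond the scatter), with acetamidomethyl in place of 1-aminoethyl on a carbonyl carbon. It is only a partial match, since the groups are not the same, but it also separates a free amino group from an acetamido group. Read in reverse, it points to a lower number for compound 4, of modest size and probably somewhat smaller than the measured step. The expected change is a 3.4-fold lower number from compound 2 to compound 4 (0.54 log units; beyond the scatter). For compound 4, the estimated value is 450 nM, with an expected range of 150 nM to 1400 nM.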

Compound 4, half-maximal effective concentration: 1010 nM
Beside the measured number, compound 4's estimate is 2.2-fold (0.35 log units) below it; low and high end bracket the measured number.
By their numbers in this assay, from the lowest: compound 1; then compounds 4 and 2 (each within the scatter of the next). At a limit, above all of these: compound 3.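

In this assay, hydrogen in place of acetyl on the amine nitrogen gives a 1.5-fold lower number from compound 2 to compound 4 (0.19 log units; within the scatter), so the free amino and acetamido forms are not separated here, which the earlier step, a 4.9-fold higher number from compound 1 to compound 2 (0.69 log units; beyond the scatter), could not show because it also changed the group on the carbonyl carbon. The separation appears instead with the methyl on the saturated chain carbon bound to an amine nitrogen and a carbonyl carbon, where hydrogen in place of methyl gives a 3.2-fold higher number from compound 1 to compound 4 (0.51 log units; beyond the scatter). No measurement shown gives a reason for either step.

Going by these compounds, whether acetyl on the amine nitrogen costs as little when that methyl is present remains open. Also open, on these data alone, is how an ethyl or isopropyl group on that chain carbon, or a dimethylamino group in place of the amino group, would read out.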